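Replacing the imidazolylmethyl arm with a lactam ring

A few compounds are considered here, and "the series" means these few. Any claim that something is new, unique, unknown or untested is made for them only; others in the source may bear on it.

Measured so far:
compound 1 `CC(C)C(Cc1ncc[nH]1)c1ccc(-c2ccc3cccc(F)c3c2)[nH]c1=O` — 11 nM
compound 2 `CCn1ncc2c(F)cc(-c3ccc(C(CC)(CC)c4nnc[nH]4)c(=O)[nH]3)cc21` — 17 nM
compound 3 `CCn1ncc2c(F)cc(-c3ccc(C(CC)(CC)c4nncn4C)c(=O)[nH]3)cc21` — 54 nM

In an assay on CHO cells for displacement of a labelled ligand from prostaglandin E2 receptor EP3 subtype (Homo sapiens), read by radioligand binding (a lower number here means a stronger inhibitor, a higher number a weaker inhibitor), compound 1 gives the lowest number of the three, but its gap to compound 2 is within the scatter, so the two cannot be placed in order; only compound 3 stands clearly beyond it. Among the measured compounds shown here, the one step measured in this set, a 3.2-fold higher number from compound 2 to compound 3 (0.50 log units; beyond the scatter), shows that capping the hydrogen-bearing nitrogen of the azole with a methyl group raised the number modestly.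

Compound 4 `CC(C)C(c1ccc(-c2ccc3cccc(F)c3c2)[nH]c1=O)N1CCCCC1=O` differs from compound 1 in one place: 2-oxopiperidin-1-yl in place of (1H-imidazol-2-yl)methyl on a saturated chain carbon bound to an aromatic carbon and a saturated chain carbon. For the measured compounds named here, no measured pair tests this change directly. The nearest hint is the step from compound 2 to compound 3, where loss of the hydrogen-bond donor on the azole cost some potency; the entering group here likewise brings no hydrogen-bond donor, and it also swaps an aromatic five-membered ring for a non-aromatic six-membered one. A modest rise in the number is therefore expected, with wide uncertainty. For compound 4 the estimate in this assay is 35 nM, within a range of 8 nM to 160 nM, which is expected to amount to a step of a 3.2-fold higher number from compound 1 to compound 4 (0.50 log units; beyond the scatter).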

Compound 4, inhibition constant: 6.4 nM
For compound 4 the middle estimate is 5.5-fold (0.74 log units) above the measured one, and the stated range ends above it.
By their numbers in this assay, from the lowest: compounds 4, 1 and 2 (each within the scatter of the next, the first and the last beyond it); then compound 3.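

In this assay, the swap on this saturated chain carbon gives a 1.7-fold lower number from compound 1 to compound 4 (0.24 log units; within the scatter), so 2-oxopiperidin-1-yl and (1H-imidazol-2-yl)methyl cannot be told apart at this place. On the core of compound 1, then, neither the five-membered aromatic ring nor the hydrogen-bond donor of the leaving group is needed to keep the number in this range, and the cost that came with capping the azole nitrogen, a 3.2-fold higher number from compound 2 to compound 3 (0.50 log units; beyond the scatter), does not carry over to this change. Nothing measured here explains why the two groups give such similar numbers.

What a plain piperidine ring, without the carbonyl, or the smaller pyrrolidin-2-one ring would give at this place remains open, so the compounds shown cannot say whether the carbonyl or the ring size matters. Also open, as far as these compounds go, is how a simple amine or a carboxylic acid would fare on this carbon, and whether 2-oxopiperidin-1-yl would do as well on the core of compound 2.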